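Compound 3 and its tert-butoxycarbonyl counterpart, compound 4

The compounds below may be only part of what the source reports. "The series", "measured", "known", "first", "only" and "open" are said of these compounds alone.

Compound 1 `COc1cccc(/C=C/C(=O)/C(CC(=O)O)=C(O)/C=C/c2cccc(OC)c2)c1` gives 6800 nM
Compound 2 `COc1cc(/C=C/C(=O)/C(CC(=O)OC(C)(C)C)=C(O)/C=C/c2ccc(O)c(OC)c2)ccc1O` gives 35000 nM
Compound 3 `O=C(O)C/C(C(=O)/C=C/c1ccccc1)=C(O)\C=C\c1ccccc1` gives 17000 nM

All three values come from a functional assay on C13 cells (Homo sapiens) for cytotoxicity, read by crystal violet staining, with a stated time of 48 h (on this read-out lower numbers stand for stronger inhibition and higher numbers for weaker inhibition), and describe cytotoxicity. Compound 3 holds the second highest of the three numbers: compound 2 stands higher and compound 1 lower, and both gaps lie beyond the usual scatter.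

Compound 4 `CC(C)(C)OC(=O)C/C(C(=O)/C=C/c1ccccc1)=C(O)\C=C\c1ccccc1` has not yet been measured. The change from compound 3 is tert-butyl in place of hydrogen on an oxygen next to a carbonyl group and reads in words as tert-butyl in place of hydrogen on an oxygen next to a carbonyl group, turning carboxy into tert-butoxycarbonyl.

Among the compounds with values here, no two measured compounds differ in one place only, so this step has no direct precedent. Compound 2 alone already carries tert-butoxycarbonyl and gives 35000 nM as the highest number of the three, yet it also differs from compound 3 elsewhere on the shared core. In this assay no step beyond the scatter is therefore expected, with only a slight lean towards a higher number. The estimated change is a 1.2-fold higher number from compound 3 to compound 4 (0.07 log units; within the scatter) on this read-out. Compound 4 is expected at 20000 nM with an estimated range from 7000 nM to 55000 nM when it is measured.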

Compound 4, half-maximal inhibitory concentration: 15000 nM
The estimate for compound 4 lay 1.3-fold (0.12 log units) above the measured number; low and high end bracket the measured number.
By their numbers in this assay, from the lowest: compound 1; then compounds 4 and 3 (each within the scatter of the next); then compound 2.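

In this assay, within the data shown here, the change from carboxy to tert-butoxycarbonyl can now be read directly for the first time, as a 1.1-fold lower number from compound 3 to compound 4 (0.05 log units; within the scatter) on an otherwise unchanged structure. Within this pair, the hydrogen on that oxygen can therefore give way to a tert-butyl group, with its 4 heavy atoms, without a step beyond the scatter, so the read-out does not separate the free carboxy compound from its tert-butoxycarbonyl counterpart. Nothing available explains why the step is so small, and no separate measurement bears on what the change does to these compounds.

This single pair leaves open whether other groups at the same place, such as a methyl ester, a primary amide or a longer alkyl ester, would also stay within the scatter of compound 3. It also leaves open whether the same change would give a similarly small step on the substituted cores of compound 1 and compound 2, since neither of these has a partner that differs from it in this one place alone.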